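A Third Methoxy on the Benzoate of Compound 2

A few compounds are considered here, and "the series" means these few. Any claim that something is new, unique, unknown or untested is made for them only; others in the source may bear on it.

Compound 1 `COC(=O)/C(=C\c1ccc(OC(=O)c2cccc(OC)c2)cc1)Sc1ccnc2cc(Cl)ccc12` and compound 2 `COC(=O)/C(=C\c1ccc(OC(=O)c2cc(OC)cc(OC)c2)cc1)Sc1ccnc2cc(Cl)ccc12` share one core and differ only by a methoxy on an aromatic carbon. In a functional assay on Jurkat E6.1 cells (Homo sapiens) for cytotoxicity, read by MTT assay, with a stated time of 24 h (on this read-out higher numbers stand for weaker inhibition and lower numbers for stronger inhibition), compound 1 gives 33300 nM, and compound 2 gives 28900 nM. Compound 2 sits alongside compound 1, the two numbers lying within the scatter of each other. The step of a 1.2-fold lower number from compound 1 to compound 2 (0.06 log units; within the scatter) therefore reads as no change. Compound 3 `COC(=O)/C(=C\c1ccc(OC(=O)c2cc(OC)cc(OC)c2OC)cc1)Sc1ccnc2cc(Cl)ccc12` carries one more methoxy: methoxy in place of hydrogen on an aromatic carbon. For the measured compounds named here, the only measured step that bears on this change is the one from compound 1 to compound 2, in which adding a methoxy to the same ring left the number within the scatter. The expected step is accordingly a 1.0-fold lower number from compound 2 to compound 3 (0.01 log units; within the scatter), which is to say none beyond the scatter. Compound 3 is thus expected to give about 28000 nM in this assay, within a range from 14000 nM to 56000 nM.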

Compound 3, half-maximal inhibitory concentration: 15600 nM
Beside the measured number, compound 3's estimate is 1.8-fold (0.25 log units) above it; measured number inside the range.
By their numbers in this assay, from the lowest: compounds 3, 2 and 1 (each within the scatter of the next, the first and the last beyond it).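

At this position, ortho to a large group, ortho to a methoxy group and para to a methoxy group, the added methoxy gives in this assay a 1.9-fold lower number from compound 2 to compound 3 (0.27 log units; within the scatter) and so stays within the scatter, as the earlier methoxy step did. For the compounds shown here, the whole change from 3-methoxyphenyl to 2,3,5-trimethoxyphenyl gives a 2.1-fold lower number from compound 1 to compound 3 (0.33 log units; beyond the scatter) and is the only step here that lies beyond the scatter, though only modestly, so a difference appears only when the two additions are read together. Nothing at hand accounts for this small difference.

The compounds shown leave open whether the number at this position depends on methoxy itself or would read the same with a hydroxyl, a fluorine or an amine. They also leave open how a longer chain, such as ethoxy, would read there.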